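A change of the carboxyphenyl end in compound 1

A few compounds are considered here, and "the series" means these few. Any claim that something is new, unique, unknown or untested is made for them only; others in the source may bear on it.

The account starts from compound 1, `Cc1c(OCCCCOc2cccc(C(=O)O)c2)ccc(C(=O)CC2CCCC2)c1O`, which carries a cyclopentyl on a saturated chain carbon bound to a carbonyl carbon and a 3-carboxyphenyl on the ether oxygen. Going by the values given here, in an assay on HEK293 cells for positive allosteric modulation of metabotropic glutamate receptor 2 (Rattus norvegicus), read by thallium flux, with a stated time of 2.5 min (a higher number here means that more compound is needed for the effect, a lower number that less compound is needed), compound 1 gives 451 nM, the highest of the three numbers known. Compound 3, `Cc1c(OCCCCOc2cccc(C(=O)O)c2)ccc(C(=O)CC(C)C)c1O`, gives 222 nM in this assay, and compound 2, `Cc1c(OCCCCOc2ccc(C(=O)CC(C)(C)C)c(O)c2C)cccc1C(=O)O`, gives 136 nM. Among the compounds with values here, the only single-point step measured, a 2.0-fold lower number from compound 1 to compound 3 (0.31 log units; beyond the scatter), concerns isopropyl in place of cyclopentyl on a saturated chain carbon bound to a carbonyl carbon and is modest. Compound 4, `Cc1cc(C(=O)O)ccc1OCCCCOc1ccc(C(=O)CC2CCCC2)c(O)c1C`, differs from compound 1 by 4-carboxy-2-methylphenyl in place of 3-carboxyphenyl on an oxygen on a saturated carbon. Within the data shown here, no measured step covers this change alone: compound 2 carries the same 4-carboxy-2-methylphenyl but also a different group on the chain carbon, so the gap from compound 1 to compound 2 shows only a combined effect. The writer therefore expects a step toward a lower number, a 1.8-fold lower number from compound 1 to compound 4 (0.26 log units; within the scatter), of uncertain size, because compound 2 with the entering group gives 136 nM. Compound 4 is estimated at 250 nM in this assay, with a range from 100 nM to 600 nM.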

Compound 4, half-maximal effective concentration: 608 nM
Compound 4: middle estimate off by 2.4-fold (0.39 log units), on the low side, and the stated range ends below it.
By their numbers in this assay, from the lowest: compounds 2 and 3 (each within the scatter of the next); then compounds 1 and 4 (each within the scatter of the next).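

In this assay, the carboxyphenyl end is now tested with the cyclopentyl on the chain carbon held fixed, and the step, a 1.3-fold higher number from compound 1 to compound 4 (0.13 log units; within the scatter), leaves the two numbers impossible to tell apart. Going by these compounds alone, with the cyclopentyl in place, then, this end on an oxygen on a saturated carbon can be 3-carboxyphenyl or 4-carboxy-2-methylphenyl with no difference that this assay can resolve, whereas the only step known before, on the chain carbon, lay beyond the scatter; the low number of compound 2, at 136 nM, therefore draws no support from this swap. Nothing given here accounts for the outcome at this end of the molecule.

The swap alters two features at once, the place of the carboxylic acid and the added methyl, so the compounds shown leave open what each does alone, which a plain 4-carboxyphenyl on the same core would help to separate. They also leave open whether this end keeps its insensitivity with isopropyl on the chain carbon, and whether a tetrazole could stand in for the carboxylic acid or a longer chain for the one linking the two ether oxygens.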